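The compounds below may be only part of what the source reports. "The series", "measured", "known", "first", "only" and "open" are said of these compounds alone.

In a functional assay on HCT-116 cells (Homo sapiens) for inhibition, read by MTT assay, with a stated time of 72 h (on this read-out lower numbers stand for stronger inhibition of growth and higher numbers for weaker inhibition of growth), compound 1 (`COC1=C(C)C(=O)C(CCCCCCCCCCn2cc(C[C@H](O)COCCOC[C@@H](O)Cc3ccc(-c4ccccc4)cc3)nn2)=C(C)C1=O`) gives 4000 nM and compound 2 (`COC1=C(OC)C(=O)C(CCCCCCn2cc(C[C@H](O)COCCOC[C@@H](O)Cc3ccc(-c4ccccc4)cc3)nn2)=C(C)C1=O`) gives 5000 nM, two numbers within the usual scatter of each other. Compound 3 (`O=C1COc2ccc(-n3cc(C[C@H](O)COCCOC[C@@H](O)Cc4ccc(-c5ccccc5)cc4)nn3)cc2N1`) gives 42500 nM. This is the highest of the three numbers and lies beyond the scatter from both others, so compound 3 inhibits growth the least of this small set.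

All three carry a different group on an aromatic nitrogen of a five-membered aromatic ring. Compound 4 (`O[C@H](COCCOC[C@@H](O)Cc1c[nH]nn1)Cc1ccc(-c2ccccc2)cc1`) has not yet been measured, and it loses the group found there in compound 3. The change from compound 3 to compound 4 is this: a hydrogen atom in place of a group of 11 heavy atoms (8 carbon, 1 nitrogen, 2 oxygen; one six-membered non-aromatic ring with 2 hetero atoms, one six-membered aromatic ring of carbon only), on an aromatic nitrogen. Going by the values given here, no measured compound has a bare ring nitrogen at that place, so the data offer no direct guide.

A small step toward a higher number is expected in this assay, and it may stay within the scatter, because compound 3 already gives 42500 nM. The estimated size of the change is a 1.3-fold higher number from compound 3 to compound 4 (0.11 log units; within the scatter). For compound 4 the expected value is 55000 nM, with an estimated range of 22000 nM to 130000 nM.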

Compound 4, concentration for 50% growth inhibition: > 100000 nM
Compound 4 gave a limit, no number; the forecaster's own chance of this, stated with the estimate: 35%; at least 1.8-fold (0.25 log units) between middle value and limit.
By their numbers in this assay, from the lowest: compounds 1 and 2 (each within the scatter of the next); then compound 3. At a limit, above all of these: compound 4.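

In this assay, compound 4 gives > 100000 nM, which is a limit of the assay and not a number. Going by these compounds alone, replacing the group of 11 heavy atoms on the aromatic nitrogen with a hydrogen atom gives an at least 2.3-fold higher number from compound 3 to compound 4 (0.37 log units; beyond the scatter), the first direct evidence that growth inhibition changes with what sits at this position, and that a bare ring nitrogen there is the poorer of these two options. The full size of this step cannot be read, and the printed figure is only its lower bound, because the result for compound 4 stops at the top of the measurable range: the limit of > 100000 nM in this assay, at which 1 of the 4 values shown sits.

This pair does not show which part of the lost group matters, whether its six-membered aromatic ring of carbon only, its six-membered non-aromatic ring with 2 hetero atoms, or simply the presence of a large group on that nitrogen. It also leaves open how a small methyl group, a plain phenyl ring, or a chain ending in an amine or a carboxylic acid would behave at this same place.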